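The source may report more compounds than this note shows. Statements on the series, on what has been measured and on what is new or still open speak of the compounds shown alone.

Measured compounds:
compound 1, `CN(C)C(=O)c1cc2cnc(Nc3ccc(NC(=O)C4(C(=O)Nc5ccccc5)CC4)cc3)nc2n1C1CCCC1`: 58%
compound 2, `CN(C)C(=O)c1cc2cnc(Nc3ccc(NC(=O)C4(C(=O)Nc5cccc(O)c5)CC4)cc3)nc2n1C1CCCC1`: -19.8%
compound 3, `CN(C)C(=O)c1cc2cnc(Nc3ccc(NC(=O)C4(C(=O)Nc5ccc(F)cc5)CC4)cc3F)nc2n1C1CCCC1`: 6.6%

In a functional assay on SiHa cells (Homo sapiens) for inhibition, read by CCK-8 assay, with a stated time of 72 h, tested at 1 uM (on this read-out higher numbers stand for more inhibition of growth at the one concentration tested and lower numbers for less inhibition of growth), compound 2 stands lowest of the three, with compound 3 nearest above it and compound 1 furthest above it. Compound 4, `CN(C)C(=O)c1cc2cnc(Nc3ccc(NC(=O)C4(C(=O)Nc5ccc(Cl)c(C(F)(F)F)c5)CC4)cc3)nc2n1C1CCCC1`, has not yet been measured. It differs from compound 2 in one place: 4-chloro-3-(trifluoromethyl)phenyl in place of 3-hydroxyphenyl on an amide-type nitrogen. For the measured compounds named here, one measured step bears on this change, a number 77.8 percentage points lower from compound 1 to compound 2 (beyond the scatter), which shows how much the hydroxy group cost. Going by the values given here, compound 4 drops that hydroxy and brings in the 4-chloro-3-(trifluoromethyl)phenyl group instead; no measured pair shows that exact exchange. Compound 4 is therefore expected to recover much of the lost ground, with a step of about a number 59.8 percentage points higher from compound 2 to compound 4 (beyond the scatter). The estimate for compound 4 is 40%, in a range from 0% to 75%.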

Compound 4, percent growth inhibition at one concentration: -11.2%
Compound 4: the middle estimate sits 51.2 percentage points above what was measured; the whole stated range lies above it.
By their numbers in this assay, from the lowest: compounds 2 and 4 (each within the scatter of the next); then compound 3; then compound 1.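

In this assay, a substituted ring on the amide-type nitrogen again falls far short of the plain phenyl, now with a group carrying no hydrogen-bond donor (a number 69.2 percentage points lower from compound 1 to compound 4 (beyond the scatter)). Exchanging 3-hydroxyphenyl for 4-chloro-3-(trifluoromethyl)phenyl leaves the two compounds indistinguishable (a number 8.6 percentage points higher from compound 2 to compound 4 (within the scatter)), so the loss seen earlier is not specific to the hydroxy group. Nothing available explains this result. The compounds shown leave open whether a chlorine alone, a trifluoromethyl alone, a methoxy group or an amine on this phenyl would retain the inhibition seen with compound 1.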